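The source may hold more compounds than are shown below. What is called first, only, known or untested is meant among the compounds shown, and "the series" means these compounds.

Three sulfonamides sharing one core have been measured in a functional assay on HT-29 cells (Homo sapiens) for antiproliferative activity, read by sulforhodamine B assay, with a stated time of 48 h; a lower number here means a stronger inhibitor, a higher number a weaker inhibitor. Compound 1 `CCc1cccc(NS(=O)(=O)c2ccc(N3CCNC3=O)cc2)c1` gives 110 nM, compound 2 `COc1ccc(NS(=O)(=O)c2ccc(N3CCNC3=O)cc2)cc1OC` gives 520 nM, and compound 3 `Cc1ccc(C)c(NS(=O)(=O)c2ccc(N3CCNC3=O)cc2)c1` gives 46 nM, the lowest number of the three, which makes it the strongest inhibitor so far.

The next compound is compound 4 `COc1ccc(NS(=O)(=O)c2ccc(N3CCNC3=O)cc2)cc1`. Its difference from compound 3 is 4-methoxyphenyl in place of 2,5-dimethylphenyl on a sulfonamide nitrogen.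

Among the measured compounds shown here, only one measured step changes this same group: a 2.4-fold lower number from compound 1 to compound 3 (0.38 log units; beyond the scatter). For the measured compounds named here, that modest step shows that the group on the sulfonamide nitrogen can shift the number, but no measured step introduces 4-methoxyphenyl. Going by the values given here, the nearest guide is compound 2, the only measured compound with methoxy on this group, at 520 nM. Among the compounds with values here, that number is well above the one for compound 3, so a rise is more likely than a further fall, and probably a larger move than the one measured.

The expected change is a 5.2-fold higher number from compound 3 to compound 4 (0.72 log units; beyond the scatter), towards a weaker inhibitor. For compound 4 the estimated value is 240 nM, with an expected range from 80 nM to 700 nM.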

Compound 4, half-maximal inhibitory concentration: 800 nM
Compound 4: middle estimate off by 3.3-fold (0.52 log units), on the low side; the measured number lies above the stated range.
By their numbers in this assay, from the lowest: compound 3; then compound 1; then compounds 2 and 4 (each within the scatter of the next).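

In this assay, changing the group on the sulfonamide nitrogen can move the number much further than the first step suggested: the swap to 4-methoxyphenyl gives a 17-fold higher number from compound 3 to compound 4 (1.24 log units; beyond the scatter) and also a 7.3-fold higher number from compound 1 to compound 4 (0.86 log units; beyond the scatter) as a step of modest size. The methoxy groups show a different picture, since a 1.5-fold higher number from compound 2 to compound 4 (0.19 log units; within the scatter) means that hydrogen in place of methoxy on an aromatic carbon leaves compound 2 and compound 4 indistinguishable, and both of these methoxy compounds print higher numbers than compound 1 and compound 3, with none of the four going against this. Nothing available explains why these groups differ in this way. Still open, going by these compounds, is how a plain phenyl group with no methoxy would compare with these four. On these data alone, a ring carrying an amine or a carboxylic acid, or a longer chain such as butyl, also remains unknown territory at this position.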